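Methoxy to Amino: A Step Without a Precedent

A few compounds are considered here, and "the series" means these few. Any claim that something is new, unique, unknown or untested is made for them only; others in the source may bear on it.

Compound 1: `COc1ccc(S(=O)(=O)NCCN2CCC(CCC(=O)c3cc(Cl)c(N)cc3OC)CC2)cc1Cl` — 158 nM
Compound 2: `COc1ccc(S(=O)(=O)NCCN2CCC(CCC(=O)c3cc(Cl)c(N)cc3OC)CC2)cc1Br` — 147 nM

In an assay on HEK293 cells for displacement of a labelled ligand from 5-hydroxytryptamine receptor 6 (Homo sapiens), with a stated time of 60 min, in the presence of a further agent that is not named here (on this read-out higher numbers stand for weaker inhibition and lower numbers for stronger inhibition), compound 1 gives 158 nM, and compound 2 gives 147 nM. On these two numbers compound 2 sits beside compound 1 rather than apart from it: the step of a 1.1-fold lower number from compound 1 to compound 2 (0.03 log units; within the scatter) lies within the scatter, so the two cannot be told apart.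

Compound 3 is `COc1cc(N)c(Cl)cc1C(=O)CCC1CCN(CCNS(=O)(=O)c2ccc(N)c(Br)c2)CC1`. Its change from compound 2 is amino in place of methoxy on an aromatic carbon. Among the measured compounds shown here, no measured step touches this change; the only step in hand, a 1.1-fold lower number from compound 1 to compound 2 (0.03 log units; within the scatter), concerns a different group at a different place and was itself within the scatter. The expectation therefore rests on little more than the neighbouring numbers, and the step of a 1.2-fold higher number from compound 2 to compound 3 (0.09 log units; within the scatter) is an estimate with a wide range rather than a prediction of direction. Compound 3 is expected to give about 180 nM, between 60 nM and 600 nM.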

Compound 3, inhibition constant: 219 nM
Beside the measured number, compound 3's estimate is 1.2-fold (0.09 log units) below it, within the range that was stated.
By their numbers in this assay, from the lowest: compounds 2, 1 and 3 (each within the scatter of the next).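

Among the compounds shown here, this is the first change at the position para to a large group, and in this assay amino in place of methoxy, ortho to a bromo group, gives a 1.5-fold higher number from compound 2 to compound 3 (0.17 log units; within the scatter). The wider change from 3-chloro-4-methoxyphenyl to 4-amino-3-bromophenyl gives a 1.4-fold higher number from compound 1 to compound 3 (0.14 log units; within the scatter), so neither step separates compound 3 from the methoxy compounds, even though methoxy counts 0 hydrogen-bond donors and amino counts 1. Nothing measured here bears on the reason for this result.

Going by these compounds, whether an acetamide or a carboxylic acid at this position would stay within the scatter remains open. So does whether amino would give a similar number with a chloro group in place of the bromo group, as a 4-amino-3-chlorophenyl group.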